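Thiazole acetic acids at prostaglandin D2 receptor 2

The source may hold more compounds than are shown below. What is called first, only, known or untested is meant among the compounds shown, and "the series" means these compounds.

Measured compounds:
compound 1, `N#Cc1cc(-c2nc(C(c3ccc(F)cc3)c3ccc(F)cc3)sc2CC(=O)O)ccc1F`, 57 nM
compound 2, `CCC(c1ccccc1)c1nc(-c2ccc(Cl)cc2)c(CC(=O)O)s1`, 190 nM

Of the compounds shown here, two sharing a carboxymethyl-bearing five-membered core have been tested in an in vitro assay on HEK385-7 cells for displacement of a labelled ligand from prostaglandin D2 receptor 2 (Homo sapiens); a lower number here means a stronger inhibitor, a higher number a weaker inhibitor. Compound 1, `N#Cc1cc(-c2nc(C(c3ccc(F)cc3)c3ccc(F)cc3)sc2CC(=O)O)ccc1F`, gives 57 nM in this assay, the lowest of the two numbers. Compound 2, `CCC(c1ccccc1)c1nc(-c2ccc(Cl)cc2)c(CC(=O)O)s1`, gives 190 nM in this assay, a higher number that lies beyond the usual scatter of such measurements. Among the compounds with values here, compound 1 therefore stands as the stronger of the pair, though with only two numbers no wider pattern can be drawn.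

Compound 3, `O=C(O)Cc1sc(C(c2ccc(F)cc2)c2ccc(F)cc2)nc1-c1ccnc(N2CCC2)c1`, has not yet been measured. It differs from compound 1 in one place: 2-(azetidin-1-yl)pyridin-4-yl in place of 3-cyano-4-fluorophenyl on an aromatic carbon. The bis(4-fluorophenyl)methyl group and the carboxymethyl group are kept, so the change is confined to the aromatic group attached to the core. Within the data shown here, no measured pair shows the effect of this kind of swap, so the expectation rests on compound 1 alone.

A modest step is expected in this assay from compound 1 to compound 3, a 1.9-fold higher number from compound 1 to compound 3 (0.29 log units; within the scatter), toward a somewhat higher number, close to the edge of the scatter. The estimate for compound 3 in this assay is 110 nM, with a range from 30 nM to 450 nM.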

Compound 3, half-maximal inhibitory concentration: 660 nM
For compound 3 the middle estimate is 6.0-fold (0.78 log units) below the measured one; the whole stated range lies below it.
By their numbers in this assay, from the lowest: compound 1; then compound 2; then compound 3.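

In this assay, the aromatic carbon next to the ring nitrogen proves sensitive to what it carries: 2-(azetidin-1-yl)pyridin-4-yl in place of 3-cyano-4-fluorophenyl gives a 12-fold higher number from compound 1 to compound 3 (1.06 log units; beyond the scatter), while the bis(4-fluorophenyl)methyl and carboxymethyl groups stay the same. Within the data shown here, this is the first step that changes a single place, and it shows that one aromatic group cannot simply be exchanged for another here without a large change in the number, since this step lies well beyond the scatter. Nothing available explains the change, and this one step cannot say which part of the exchange accounts for it.

The swap removes the nitrile and the fluorine and brings in the pyridine nitrogen and the azetidine all at once, so the contribution of each remains unresolved. On these data alone, it remains open whether an unsubstituted phenyl, a 3-cyanophenyl, or a pyridin-4-yl carrying a methoxy or dimethylamino group in place of the azetidine would give a number closer to that of compound 1 or to that of compound 3.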